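This account rests on a few compounds, and the source may have more. Where it says the series, first, only, none or still open, it means among the compounds named here.

Measured compounds:
Compound 1, `CN1C/C(=C\c2ccccc2)C(=O)[C@]2(C1)[C@@H](c1ccccc1)CN(C)[C@@]21C(=O)N(C)c2ccccc21`: 68.8%
Compound 2, `Cc1ccc(/C=C2\CN(C)C[C@@]3(C2=O)[C@@H](c2ccc(C)cc2)CN(C)[C@@]32C(=O)Nc3ccccc32)cc1`: 50.7%

Both numbers come from a functional assay on the whole organism (strain Wister albino) for inhibition, with Rattus norvegicus as the target, read by paw edema, with stated times of 1 h and 4 h, at a dose of 50 mg/kg by the intraperitoneal route; a lower number here means less inhibition, a higher number more inhibition at the dose given (going by the name of the read-out). Compound 2 stands lowest of the two; compound 1 is the only other point, and its number is higher by a margin beyond the usual scatter. Compound 1 and compound 2 differ in more than one place, so their gap cannot be assigned to any single change. Compound 3, `Cc1ccc(/C=C2\CN(C)C[C@@]3(C2=O)[C@@H](c2ccc(C)cc2)CN(C)[C@@]32C(=O)N(C)c3ccccc32)cc1`, is not yet measured in this assay. It differs from compound 2 in one place only: methyl in place of hydrogen on an amide-type nitrogen in a ring. Going by the values given here, no single-change step between measured compounds exists in this set to size the effect of that exchange. The expectation is a small rise, at or just beyond the scatter; the step is estimated as a number 8.3 percentage points higher from compound 2 to compound 3 (within the scatter). Compound 3 is therefore expected to give 59% in this assay, with a range of 46% to 72%.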

Compound 3, a percentage reported as inhibition, in the whole organism at one dose (the size of the read-out at that dose, not a potency): 68.8%
The estimate for compound 3 lay 9.8 percentage points below the measured number; the measured number falls inside the stated range.
By their numbers in this assay, from the lowest: compound 2; then compounds 1 and 3 (each within the scatter of the next).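

In this assay, methyl in place of hydrogen on the amide-type nitrogen in a ring gives the series its first single-change reading, a number 18.1 percentage points higher from compound 2 to compound 3 (beyond the scatter) with everything else held constant. With the rest of the structure as in compound 2, the amide hydrogen is not required for inhibition at this dose, and this site, two ring bonds from the ring atom that bears two fused rings, is one where a single carbon moves the read-out. No measurement here bears on the reason for this step.

From the compounds shown here alone, whether an ethyl group, a benzyl group or a longer chain ending in an amine on this nitrogen would go further or fall back remains open. This single pair also leaves open whether methyl gives a similar step with other aryl groups on the shared core.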